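Para-halogen analogues: from fluoro to chloro

The source may hold more compounds than are shown below. What is called first, only, known or untested is meant among the compounds shown, and "the series" means these compounds.

Values in a functional assay on NCI-H460 cells (Homo sapiens) for cytotoxicity, read by MTT assay, with a stated time of 72 h (on this read-out lower numbers stand for stronger inhibition and higher numbers for weaker inhibition), are as follows
- Compound 1 `Cc1ccc(S(=O)(=O)n2cc(COC3=C/C(=N\c4ccc(I)cc4)c4ccccc4C3=O)nn2)cc1` gives > 16300 nM (a limit)
- Compound 2 `Cc1ccc(/N=C2\C=C(OCc3cn(S(=O)(=O)c4ccc(C)cc4)nn3)C(=O)c3ccccc32)cc1` gives 8020 nM
- Compound 3 `Cc1ccc(S(=O)(=O)n2cc(COC3=C/C(=N\c4ccc(F)cc4)c4ccccc4C3=O)nn2)cc1` gives 7360 nM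

Compound 3 at 7360 nM is level with compound 2 within the scatter. The gap between the two numbers is a 1.1-fold lower number from compound 2 to compound 3 (0.04 log units; within the scatter) and sets no order.

The next analogue is compound 4 `Cc1ccc(S(=O)(=O)n2cc(COC3=C/C(=N\c4ccc(Cl)cc4)c4ccccc4C3=O)nn2)cc1` with the change chloro in place of fluoro on an aromatic carbon in which chloro takes the place of fluoro on an aromatic carbon, para to a large group. The same change reads as 4-fluorophenyl to 4-chlorophenyl.

Chloro has not been measured in this series. Two further steps at the same place start from iodo: an at least 2.2-fold lower number from compound 1 to compound 3 (0.34 log units; beyond the scatter) and an at least 2.0-fold lower number from compound 1 to compound 2 (0.30 log units; that floor lies within the scatter) give floors only. The expectation therefore rests mainly on compound 3 at 7360 nM and on the small gap a 1.1-fold lower number from compound 2 to compound 3 (0.04 log units; within the scatter) between the two numbers.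

The expected change in this assay is a 1.2-fold higher number from compound 3 to compound 4 (0.06 log units; within the scatter) and so none beyond the scatter, with any drift more likely toward higher numbers.

Compound 4 is estimated at 8500 nM with an expected range from 4500 nM to 16000 nM as the working figure.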

Compound 4, half-maximal inhibitory concentration: 12100 nM
Beside the measured number, compound 4's estimate is 1.4-fold (0.15 log units) below it; low and high end bracket the measured number.
By their numbers in this assay, from the lowest: compounds 3, 2 and 4 (each within the scatter of the next). At a limit, above all of these: compound 1.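

At this position in this assay, chloro gives a third exact number alongside fluoro and methyl: a 1.6-fold higher number from compound 3 to compound 4 (0.22 log units; within the scatter) and a 1.5-fold higher number from compound 2 to compound 4 (0.18 log units; within the scatter) both stay within the scatter, so the three groups cannot be ordered. The change from 4-fluorophenyl to 4-chlorophenyl therefore opens no measurable gap, and the earlier fluoro and methyl pair alone could not show this for a second halogen. The comparison with iodo supplies only a floor that sets no order: an at least 1.3-fold lower number from compound 1 to compound 4 (0.12 log units; that floor lies within the scatter).

From the compounds shown here alone, how iodo truly compares stays open, since compound 1 sits at a limit: the limit of > 16300 nM in this assay, at which 1 of the 4 values shown sits. Going by these compounds, whether a group of another kind at this place, such as an amine or a carboxylic acid, would move the number beyond the scatter of these values also remains open.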